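Moving and Swapping the Benzyloxy Substituent of Compound 1

This account rests on a few compounds, and the source may have more. Where it says the series, first, only, none or still open, it means among the compounds named here.

Compound 1 `FC(F)(F)c1ccc(CN2CCN(Cc3cc(-c4ccc(OCc5ccccc5Cl)cc4)on3)CC2)cc1` is one of three measured compounds that share a common core and differ only in the group sitting on a saturated chain carbon bound to an oxygen on an aromatic ring. In a functional assay on Huh-7 cells (Homo sapiens) for antiproliferative activity, read by sulforhodamine B assay, with a stated time of 72 h (a higher number here means a weaker inhibitor, a lower number a stronger inhibitor), compound 1 gives 1000 nM, the highest number of the three. Compound 2 `FC(F)(F)c1ccc(CN2CCN(Cc3cc(-c4ccc(OCc5cccc(Cl)c5)cc4)on3)CC2)cc1` carries a 3-chlorophenyl there and gives 200 nM; compound 3 `N#Cc1cccc(COc2ccc(-c3cc(CN4CCN(Cc5ccc(C(F)(F)F)cc5)CC4)no3)cc2)c1` carries a 3-cyanophenyl and gives 100 nM. The step of a 5.0-fold lower number from compound 1 to compound 2 (0.70 log units; beyond the scatter) and the step of a 10-fold lower number from compound 1 to compound 3 (1.00 log units; beyond the scatter) both point the same way, while the step of a 2.0-fold lower number from compound 2 to compound 3 (0.30 log units; within the scatter) shows that cyano and chloro on an aromatic carbon give numbers within the scatter of each other. Compound 4 `COc1ccc(COc2ccc(-c3cc(CN4CCN(Cc5ccc(C(F)(F)F)cc5)CC4)no3)cc2)cc1` has not yet been measured; it differs from compound 1 by 4-methoxyphenyl in place of 2-chlorophenyl on a saturated chain carbon bound to an oxygen on an aromatic ring. Going by the values given here, no measured step covers a 4-methoxyphenyl, so the two earlier steps bear on it only in part: they show that replacing the 2-chlorophenyl lowered the number, but say nothing about a methoxy or its location. A modest lowering is therefore expected, a 3.3-fold lower number from compound 1 to compound 4 (0.52 log units; beyond the scatter). For compound 4 the expected value is 300 nM, with a range from 100 nM to 1000 nM.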

Compound 4, half-maximal inhibitory concentration: 3200 nM
For compound 4 the middle estimate is 11-fold (1.03 log units) below the measured one, outside the stated range (above it).
By their numbers in this assay, from the lowest: compounds 3 and 2 (each within the scatter of the next); then compound 1; then compound 4.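

The earlier compounds shown here left room to think that any replacement of the 2-chlorophenyl on this saturated chain carbon lowers the number, but the 4-methoxyphenyl goes the other way in this assay (a 3.2-fold higher number from compound 1 to compound 4 (0.51 log units; beyond the scatter)). Compound 4 is therefore the weakest of the four, and the change matters even more when it is set against the two compounds with a substituent at the 3-position of the ring (a 32-fold higher number from compound 3 to compound 4 (1.51 log units; beyond the scatter); a 16-fold higher number from compound 2 to compound 4 (1.20 log units; beyond the scatter)). No measurement shown accounts for this reversal, so the result records what happens at this position but gives no reason for it.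

Whether the higher number belongs to the methoxy itself or to its location stays open, since the compounds shown include neither a 3-methoxyphenyl nor a 4-chlorophenyl to separate the two. Also open, from the compounds shown here alone, is how a ring carrying an amine or a carboxylic acid would fare at this position, and whether a 3-substituted ring generally gives lower numbers than a 4-substituted one.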